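Chalcone-stilbene series: alkoxy chain length and HepG2 antiproliferation

The source may report more compounds than this note shows. Statements on the series, on what has been measured and on what is new or still open speak of the compounds shown alone.

Measured compounds:
compound 1 `CCOc1ccc(C(=O)/C=C/c2c(/C=C/c3ccc(OC)cc3)cc(OC)cc2OC)cc1` — 8 ug/mL
compound 2 `CCCCCCOc1ccc(C(=O)/C=C/c2c(/C=C/c3ccc(OC)cc3)cc(OC)cc2OC)cc1` — 16.2 ug/mL
compound 3 `COc1ccc(/C=C/c2cc(OC)cc(OC)c2/C=C/C(=O)c2ccc(OC)cc2)cc1` — 4.9 ug/mL

In a functional assay on HepG2 cells (Homo sapiens) for antiproliferative activity, read by MTT assay, with a stated time of 48 h (a lower number here means a stronger inhibitor, a higher number a weaker inhibitor), compound 3 gives the lowest number of the three. Its nearest neighbour is compound 1, and the step of a 1.6-fold lower number from compound 1 to compound 3 (0.21 log units; within the scatter) is within the scatter, so the two cannot be ordered. Against compound 2 the step of a 3.3-fold lower number from compound 2 to compound 3 (0.52 log units; beyond the scatter) is beyond the scatter.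

Compound 4 `CCCCCCCCCCCCOc1ccc(C(=O)/C=C/c2c(/C=C/c3ccc(OC)cc3)cc(OC)cc2OC)cc1` is not yet measured. It differs from compound 3 by undecyl in place of hydrogen on a saturated chain carbon bound to an oxygen on an aromatic ring, the change sitting on a saturated chain carbon bound to an oxygen on an aromatic ring.

Going by the values given here, the steps that bear on it are those extending the same chain: a 2.0-fold higher number from compound 1 to compound 2 (0.31 log units; beyond the scatter) and the reverse of a 3.3-fold lower number from compound 2 to compound 3 (0.52 log units; beyond the scatter). Each lengthening of the chain at this position has raised the number in this assay, with the larger extension giving the larger rise. Undecyl is a far longer addition than pentyl, so a further rise beyond the scatter is expected, though its size is uncertain because a 2.0-fold higher number from compound 1 to compound 2 (0.31 log units; beyond the scatter) was only modest.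

Compound 4 is therefore expected to give 30 ug/mL, with a range of 12 ug/mL to 80 ug/mL, a step of a 6.1-fold higher number from compound 3 to compound 4 (0.79 log units; beyond the scatter) from compound 3.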

Compound 4, half-maximal inhibitory concentration: 11.6 ug/mL
The estimate for compound 4 lay 2.6-fold (0.41 log units) above the measured number; measured number below the stated range.
By their numbers in this assay, from the lowest: compounds 3, 1, 4 and 2 (each within the scatter of the next, the first and the last beyond it).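

In this assay, the number no longer follows chain length at this position: a 2.4-fold higher number from compound 3 to compound 4 (0.37 log units; beyond the scatter) is still beyond the scatter, but with a 1.4-fold lower number from compound 2 to compound 4 (0.15 log units; within the scatter) and a 1.5-fold higher number from compound 1 to compound 4 (0.16 log units; within the scatter) both within it, compound 4 cannot be ordered against compound 2 or compound 1. A rise with every lengthening of the chain therefore does not hold across the series, and compound 4 goes against it. Undecyl in place of hydrogen on a saturated chain carbon bound to an oxygen on an aromatic ring thus brings only a modest step from compound 3, despite its size.

Nothing in the data at hand accounts for this result. Still open, on these data alone, is how the number behaves with chains of intermediate length, with a chain longer than dodecyl, and with a chain carrying an amine or a carboxylic acid.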